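The source may hold more compounds than are shown below. What is called first, only, known or untested is meant among the compounds shown, and "the series" means these compounds.

Working notes on the series

The three measured compounds share one core and differ only in the aryl group on a saturated chain carbon bound to a sulfur. Compound 1 `COc1cc(-c2nnc(SCc3ccc(C)cc3)o2)ccc1O` carries a 4-methylphenyl there, and in an ADME assay on cells (Mus musculus, strain BALB/c) for cytotoxicity, read by MTT assay, with a stated time of 24 h (on this read-out lower numbers stand for higher toxicity in this test and higher numbers for lower toxicity in this test), compound 1 gives 549000 nM, the highest of the three numbers. Compound 2 `COc1cc(-c2nnc(SCc3cccc(Cl)c3)o2)ccc1O` carries a 3-chlorophenyl, and in this assay compound 2 gives 470000 nM. Compound 3 `COc1cc(-c2nnc(SCc3ccccc3Br)o2)ccc1O` carries a 2-bromophenyl, and in this assay compound 3 gives 363000 nM. All three steps are small: a 1.2-fold lower number from compound 1 to compound 2 (0.07 log units; within the scatter), a 1.5-fold lower number from compound 1 to compound 3 (0.18 log units; within the scatter) and a 1.3-fold lower number from compound 2 to compound 3 (0.11 log units; within the scatter). Going by the values given here, no compound can be set apart from another on these numbers.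

Compound 4 `COc1cc(-c2nnc(SCc3ccccc3Cl)o2)ccc1O` is not yet measured. Its difference from compound 1 is 2-chlorophenyl in place of 4-methylphenyl on a saturated chain carbon bound to a sulfur. The expectation for compound 4 rests mainly on a 1.5-fold lower number from compound 1 to compound 3 (0.18 log units; within the scatter), where a 2-bromophenyl entered in the same place, and on a 1.2-fold lower number from compound 1 to compound 2 (0.07 log units; within the scatter), where a 3-chlorophenyl entered; both stayed within the scatter. No step beyond the scatter is therefore expected in this assay for compound 4. The expected step is a 1.4-fold lower number from compound 1 to compound 4 (0.14 log units; within the scatter). Compound 4 is estimated to give about 400000 nM in this assay, with a range from 200000 nM to 800000 nM.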

Compound 4, half-maximal cytotoxic concentration: 564000 nM
For compound 4 the middle estimate is 1.4-fold (0.15 log units) below the measured one; low and high end bracket the measured number.
By their numbers in this assay, from the lowest: compounds 3, 2, 1 and 4 (each within the scatter of the next).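

The step from a methyl-bearing ring to a chlorine-bearing ring on a saturated chain carbon bound to a sulfur now has a direct reading in this assay: a 1.0-fold higher number from compound 1 to compound 4 (0.01 log units; within the scatter). Two comparisons are new to the series: chloro in place of bromo on an aromatic carbon gives a 1.6-fold higher number from compound 3 to compound 4 (0.19 log units; within the scatter), and 2-chlorophenyl in place of 3-chlorophenyl gives a 1.2-fold higher number from compound 2 to compound 4 (0.08 log units; within the scatter). Neither the kind of halogen nor the difference between the 2-chlorophenyl and 3-chlorophenyl groups therefore separates these compounds, and all four aryl groups remain indistinguishable in this assay.

No measurement at hand explains why the four numbers stay together. Still open, going by these compounds, is whether a group of another kind on the same saturated chain carbon, such as an amine, a carboxylic acid or a longer chain in place of the aryl group, would give a step beyond the scatter in this assay.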